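Compound 3: Two Chlorines Enter the Ring on the Carbonyl

The compounds below may be only part of what the source reports. "The series", "measured", "known", "first", "only" and "open" are said of these compounds alone.

Within the data shown here, in a functional assay on B16-F10 cells (Mus musculus) for antiproliferative activity, read by MTT assay, with a stated time of 48 h (a lower number here means a stronger inhibitor, a higher number a weaker inhibitor), compound 2 `COc1ccc(/C=C/c2cc(OC)cc(OC)c2/C=C/C(=O)c2ccccc2)cc1` gives 3.7 ug/mL, the lowest of the two numbers known so far; compound 1 `CCOc1ccc(C(=O)/C=C/c2c(/C=C/c3ccc(OC)cc3)cc(OC)cc2OC)cc1` gives 6.4 ug/mL, and the step of a 1.7-fold lower number from compound 1 to compound 2 (0.24 log units; within the scatter) separates the pair. Compound 3 `COc1ccc(/C=C/c2cc(OC)cc(OC)c2/C=C/C(=O)c2ccc(Cl)c(Cl)c2)cc1` differs from compound 2 in one place: 3,4-dichlorophenyl in place of phenyl on a carbonyl carbon. Among the measured compounds shown here, no measured step touches the ring on the carbonyl carbon, since the single known step concerns hydrogen in place of ethoxy on an aromatic carbon, so the expectation rests on compound 2 alone. Compound 3 is expected to give 3 ug/mL, within 1.2 ug/mL to 7.5 ug/mL, an expected step of a 1.2-fold lower number from compound 2 to compound 3 (0.09 log units; within the scatter) that stays within the scatter.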

Compound 3, half-maximal inhibitory concentration: 7.5 ug/mL
Compound 3: the middle estimate sits 2.5-fold (0.40 log units) below what was measured; measured number inside the range.
By their numbers in this assay, from the lowest: compounds 2, 1 and 3 (each within the scatter of the next, the first and the last beyond it).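

In this assay the ring on the carbonyl carbon proves able to move the number beyond the scatter: 3,4-dichlorophenyl in place of phenyl gives a 2.0-fold higher number from compound 2 to compound 3 (0.31 log units; beyond the scatter) and this step is modest. Set against 4-ethoxyphenyl at the same place, 3,4-dichlorophenyl gives a 1.2-fold higher number from compound 1 to compound 3 (0.07 log units; within the scatter) so these two substituted rings are not told apart here. As far as these compounds go, whether a ring carrying a single chlorine, an amine or a carboxylic acid at this place would stay near compound 2 remains open. No measurement shown here accounts for either step.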